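This account rests on a few compounds, and the source may have more. Where it says the series, first, only, none or still open, it means among the compounds named here.

Compound 1 `O=C(O)c1ccc(COc2ccc(/C=C3\SC(=S)N(c4ccc([N+](=O)[O-])cc4)C3=O)cc2)cc1` sits at the weak end of what has been measured. In an assay on isolated protein for inhibition of Apoptosis regulator Bcl-2 (Homo sapiens), read by fluorescence polarization (on this read-out lower numbers stand for stronger inhibition and higher numbers for weaker inhibition), compound 1 gives > 10000 nM, which is a limit of the assay and not a number (the limit of > 10000 nM in this assay, at which 1 of the 2 values shown sits). Compound 2 `O=C(O)c1ccc([N+](=O)[O-])c(COc2ccc(/C=C3\SC(=S)N(c4ccc([N+](=O)[O-])cc4)C3=O)cc2)c1` gives 3100 nM in this assay, and the step of an at least 3.2-fold lower number from compound 1 to compound 2 (0.50 log units; beyond the scatter) alters the carboxyphenyl end of the molecule, not the aryl on the ring nitrogen. Compound 3 `Cc1ccc(N2C(=O)/C(=C/c3ccc(OCc4ccc(C(=O)O)cc4)cc3)SC2=S)cc1` differs from compound 1 by methyl in place of nitro on an aromatic carbon. Among the measured compounds shown here, no measured step touches that aryl; nothing here sets a direction for it. Compound 3 is expected to remain near the limit, with a step that the limit leaves unreadable from compound 1 to compound 3 expected. Compound 3 is estimated at 15000 nM, between 5000 nM and 50000 nM.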

Compound 3, inhibition constant: > 10000 nM
Compound 3: a limit, no number; the forecaster's own chance of this, stated with the estimate: 60%; the middle value is on the limit's open side.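

Compound 1 and compound 3 both stand at a limit of the assay, not at a number, so no step between them can be read: the limit of > 10000 nM in this assay, at which 2 of the 3 values shown sit.

On these data alone, whether 4-nitrophenyl or 4-methylphenyl gives stronger inhibition in this assay stays open.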